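The source may hold more compounds than are shown below. What is called first, only, known or untested is meant among the compounds shown, and "the series" means these compounds.

Of the compounds shown here, two have been tested in a functional assay on SF-295 cells (Homo sapiens) for inhibition; on this read-out higher numbers stand for weaker inhibition of growth and lower numbers for stronger inhibition of growth. Compound 1, with the structure `COc1cc(/C=C/C(=O)c2cccc(-n3cc(-c4ccc(Cl)cc4)[nH]c3=O)c2)cc(OC)c1OC`, gives 24300 nM in this assay, the higher of the two numbers recorded. Compound 2, whose structure is `COc1cc(/C=C/C(=O)c2cccc(-n3cc(-c4ccccc4)[nH]c3=O)c2)ccc1O`, gives 3040 nM in this assay, a number that lies well below that of compound 1, beyond the usual scatter; the two compounds differ in more than one place, so the gap cannot be tied to a single change.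

Compound 3, with the structure `COc1cc(/C=C/C(=O)c2cccc(-n3cc(-c4ccccc4)[nH]c3=O)c2)cc(OC)c1OC`, has not yet been tested. It is obtained from compound 1 by a single change: hydrogen in place of chloro on an aromatic carbon. Among the compounds with values here, no measured pair in this set shows exactly this change on its own, so its effect cannot be read off directly. The step from compound 1 to compound 3 is expected to be a modest move toward stronger growth inhibition, a 2.0-fold lower number from compound 1 to compound 3 (0.31 log units; beyond the scatter), at the edge of the scatter. Compound 3 is therefore estimated to give 12000 nM in this assay, with a likely range from 4000 nM to 40000 nM.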

Compound 3, concentration for 50% growth inhibition: 1900 nM
The estimate for compound 3 lay 6.3-fold (0.80 log units) above the measured number; measured number outside the range, below it.
By their numbers in this assay, from the lowest: compounds 3 and 2 (each within the scatter of the next); then compound 1.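

In this assay, exchanging the chloro group for hydrogen on an aromatic carbon, para to a large group, turns 4-chlorophenyl into phenyl and gives a 13-fold lower number from compound 1 to compound 3 (1.11 log units; beyond the scatter), a large step. The two earlier compounds differ in more than one place, so they could not tie any gap in growth inhibition to one position; this pair shows that losing a single heavy atom at this position, with the rest of the molecule unchanged, is enough to shift the read-out well beyond the usual scatter. The step describes only what happens in this one pair, and nothing available here accounts for its size.

The compounds shown place only chloro and hydrogen at this position, so it remains open how a different group there, such as fluoro, methoxy or an amine, would compare with either of them. Within the data shown here, it is also open whether the same exchange would have a similar effect on a compound with another substitution pattern on the ring carrying the methoxy groups, such as the one in compound 2.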